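The source may report more compounds than this note shows. Statements on the series, on what has been measured and on what is new or still open speak of the compounds shown alone.

Compound 1 `CC(=O)c1ccccc1OC1CCN(c2ccc(-n3ccnc3)nn2)CC1` gives 34 nM in an assay on microsomes from liver for inhibition of acyl-CoA desaturase 1 (Rattus norvegicus); a higher number here means a weaker inhibitor, a lower number a stronger inhibitor.
Compound 2 `c1cn(-c2ccc(N3CCC(Oc4ccc5c(c4)CCC5)CC3)nn2)cn1` gives 62 nM in this assay.
Compound 3 `FC(F)(F)c1cccc(OC2CCN(c3ccc(-n4ccnc4)nn3)CC2)c1` gives 19 nM in this assay.

Compound 3 carries the lowest of the three numbers. Against compound 1 the gap is within the scatter, so the two cannot be told apart; against compound 2 the gap lies beyond the scatter.

Compound 4 `CCc1cccc(OC2CCN(c3ccc(-n4ccnc4)nn3)CC2)c1` differs from compound 3 in one place: ethyl in place of trifluoromethyl on an aromatic carbon. The shared core and the oxygen on a saturated carbon stay as they are.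

Within the data shown here, only one measured step exists, a 1.8-fold higher number from compound 1 to compound 2 (0.26 log units; within the scatter), and it swaps an entire aryl group rather than one substituent on the ring, so it says little about the present change; it does show that a sizeable alteration at this end left the number within the scatter. Among the measured compounds shown here, no measured step exchanges trifluoromethyl for another group, so there is no direct precedent. The expectation is therefore no step beyond the scatter, and the estimated step is a 1.6-fold higher number from compound 3 to compound 4 (0.20 log units; within the scatter). Compound 4 is expected to give 30 nM, in a range from 10 nM to 90 nM.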

Compound 4, half-maximal inhibitory concentration: 38 nM
Beside the measured number, compound 4's estimate is 1.3-fold (0.10 log units) below it; the measured number falls inside the stated range.
By their numbers in this assay, from the lowest: compounds 3, 1, 4 and 2 (each within the scatter of the next, the first and the last beyond it).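

In this assay, the exchange of ethyl for trifluoromethyl on an aromatic carbon is the only step shown that changes a single substituent on this ring, and it gives a small difference (a 2.0-fold higher number from compound 3 to compound 4 (0.30 log units; within the scatter)), so the two groups cannot be told apart at this place. The larger exchanges of the whole group on the oxygen also stay small (a 1.6-fold lower number from compound 2 to compound 4 (0.21 log units; within the scatter); a 1.1-fold higher number from compound 1 to compound 4 (0.05 log units; within the scatter)), so 3-ethylphenyl cannot be told apart from 2,3-dihydro-1H-inden-5-yl or 2-acetylphenyl here. No supporting measurement bears on why these numbers lie so close.

The compounds shown leave open whether an amine or a carboxylic acid at this place on the ring would stay as close. They also leave open what a longer chain such as butyl would do.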